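From Piperazin-1-yl to (Pyridin-2-yl)amino: an Expected Inhibition Value

The source may hold more compounds than are shown below. What is called first, only, known or untested is meant among the compounds shown, and "the series" means these compounds.

Three measured compounds share one core and a saturated chain. Compound 1 `COc1ccccc1N1CCN(CC2(C)CCc3c(C)c(O)c(C)c(C)c3O2)CC1` gives 1000 nM in a functional assay (brain) for inhibition, with Rattus norvegicus as the target; a higher number here means a weaker inhibitor, a lower number a stronger inhibitor. Compound 2 `Cc1c(C)c2c(c(C)c1O)CCC(C)(CN1CCN(c3ccc(Cl)cc3)CC1)O2` gives 900 nM, and compound 3 `Cc1c(C)c2c(c(C)c1O)CCC(C)(CN1CCNCC1)O2`, bearing hydrogen on an amine nitrogen in a ring, gives 1000 nM. Compound 3 stands level with compound 1, the two together the highest of the three numbers; a 1.1-fold lower number from compound 1 to compound 2 (0.05 log units; within the scatter), no change at the digits printed from compound 1 to compound 3 (within the scatter) and a 1.1-fold higher number from compound 2 to compound 3 (0.05 log units; within the scatter) all lie within the scatter. Compound 4 `Cc1c(C)c2c(c(C)c1O)CCC(C)(CNc1ccccn1)O2` differs from compound 3 by (pyridin-2-yl)amino in place of piperazin-1-yl on a saturated chain carbon bound to a saturated ring carbon. Among the measured compounds shown here, no measured step touches that chain carbon. Because no change at the digits printed from compound 1 to compound 3 (within the scatter) and a 1.1-fold higher number from compound 2 to compound 3 (0.05 log units; within the scatter) lie within the scatter while changing only what hangs on the ring amine nitrogen, the step of no change at the digits printed from compound 3 to compound 4 (within the scatter) is expected to be small, with no clear direction. Compound 4 is estimated at 1000 nM, in a range from 300 nM to 4000 nM.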

Compound 4, half-maximal inhibitory concentration: 200 nM
Beside the measured number, compound 4's estimate is 5.0-fold (0.70 log units) above it; the whole stated range lies above it.
By their numbers in this assay, from the lowest: compound 4; then compounds 2, 1 and 3 (each within the scatter of the next).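

In this assay, among the compounds shown here, placing (pyridin-2-yl)amino instead of piperazin-1-yl on the saturated chain carbon gives a 5.0-fold lower number from compound 3 to compound 4 (0.70 log units; beyond the scatter), the only step so far that lies beyond the scatter. For the compounds shown here, the earlier steps changed only what hangs on the ring amine nitrogen and stayed within the scatter, so this chain carbon is the first place where a change shifts the number. Nothing shown gives a reason for this shift.

From the compounds shown here alone, it remains open whether the pyridine ring is needed or whether any aromatic ring would do. A phenylamino group on the same chain carbon would test this.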